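A few compounds are considered here, and "the series" means these few. Any claim that something is new, unique, unknown or untested is made for them only; others in the source may bear on it.

Compound 1 `CCCCC(O)c1cccc(NC(=O)NC(=O)CC)c1` is tested in a functional assay on MCF7 cells (Homo sapiens) for antiproliferative activity, with a stated time of 48 h; on this read-out lower numbers stand for stronger inhibition and higher numbers for weaker inhibition. In this assay compound 1 gives > 100000 nM, which is a limit of the assay rather than a number. Compound 2 `CCCCC(OC)c1cccc(NC(=O)NC(=O)CC)c1`, which carries methyl in place of hydrogen on an oxygen on a saturated carbon, gives > 100000 nM in this assay, again a limit. The step from compound 1 to compound 2, a step that the two limits leave unreadable from compound 1 to compound 2, is not readable because both values sit at the limit of > 100000 nM in this assay, at which 2 of the 2 values shown sit. Compound 3 `C=CC(=O)Nc1cccc(C(O)CCCC)c1` differs from compound 1 by vinyl in place of propanoylamino on a carbonyl carbon. Among the measured compounds shown here, no measured step bears on this change, so the expectation rests on compound 1 alone. Compound 3 is estimated at 50000 nM, within a range from 5000 nM to 200000 nM. This estimate means an expected step of an at least 2.0-fold lower number from compound 1 to compound 3 (0.30 log units; that floor lies within the scatter).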

Compound 3, half-maximal inhibitory concentration: > 100000 nM
Compound 3 was reported as a limit; the forecaster's own chance of this, stated with the estimate: 50%; middle value at least 2.0-fold (0.30 log units) from the limit.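

Among the compounds shown here, compound 3 also gives only a limit of the assay, so no step from compound 1 to compound 3 can be read, because all values sit at the same limit: the limit of > 100000 nM in this assay, at which 3 of the 3 values shown sit. In this assay the compounds shown leave open which change to the shared core, if any, would give a readable value.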